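Aryl variation on the ring nitrogen, estimate for compound 4

A few compounds are considered here, and "the series" means these few. Any claim that something is new, unique, unknown or untested is made for them only; others in the source may bear on it.

Measured compounds:
- compound 1 `Cc1cc2occ(-c3nc(-c4ccccc4)c(-c4ccccc4)n3-c3ccc([N+](=O)[O-])cc3)c(=O)c2cc1Cl`; in a functional assay on A549 cells (Homo sapiens) for inhibition, read by MTT assay, with a stated time of 72 h (a higher number here means a weaker inhibitor, a lower number a stronger inhibitor), compound 1 gives 3130 nM
- compound 2 `Cc1cc2occ(-c3nc(-c4ccccc4)c(-c4ccccc4)n3-c3ccc(Cl)c(Cl)c3)c(=O)c2cc1Cl`; in this assay compound 2 gives 6250 nM
- compound 3 `Cc1cc2occ(-c3nc(-c4ccccc4)c(-c4ccccc4)n3-c3ccccc3Cl)c(=O)c2cc1Cl`; in this assay compound 3 gives 12500 nM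

Compound 2 stands second highest of the three numbers, with compound 1 nearest and compound 3 furthest, and its gap to each of them is within the scatter. The steps across the aryl group on the ring nitrogen are small: a 2.0-fold higher number from compound 1 to compound 2 (0.30 log units; within the scatter) and a 2.0-fold higher number from compound 2 to compound 3 (0.30 log units; within the scatter); only the combined step a 4.0-fold higher number from compound 1 to compound 3 (0.60 log units; beyond the scatter) goes beyond the scatter.

Compound 4 `Cc1cc2occ(-c3nc(-c4ccccc4)c(-c4ccccc4)n3-c3ccc(Br)cc3)c(=O)c2cc1Cl` differs from compound 2 as follows: 4-bromophenyl in place of 3,4-dichlorophenyl on an aromatic nitrogen. Going by the values given here, no measured step contains a bromine, so the change has no direct precedent here. Among the compounds with values here, since every single aryl exchange so far moved the number by no more than the step from compound 1 to compound 2, the step is expected to stay within the scatter, as a 1.4-fold lower number from compound 2 to compound 4 (0.14 log units; within the scatter) shows, leaning toward a lower number. Compound 4 is therefore estimated at 4500 nM, within 2000 nM to 12000 nM.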

Compound 4, half-maximal inhibitory concentration: 25000 nM
Estimate against measurement, compound 4: 5.6-fold (0.74 log units) below, and the stated range ends below it.
By their numbers in this assay, from the lowest: compounds 1, 2, 3 and 4 (each within the scatter of the next, the first and the last beyond it).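

Within this assay, the exchange of 3,4-dichlorophenyl for 4-bromophenyl gives a 4.0-fold higher number from compound 2 to compound 4 (0.60 log units; beyond the scatter), while the exchange of 2-chlorophenyl for 4-bromophenyl gives a 2.0-fold higher number from compound 3 to compound 4 (0.30 log units; within the scatter). The widest step in the set is now an 8.0-fold higher number from compound 1 to compound 4 (0.90 log units; beyond the scatter), and it joins two aryl groups each carrying one substituent, 4-nitrophenyl and 4-bromophenyl, so the group on the aryl ring moves the number even when its place is unchanged. No measurement here accounts for these steps.

The compounds shown leave open where the plain phenyl group or 4-chlorophenyl would fall on this scale, the latter being a direct comparison with 4-bromophenyl. Also open, going by these compounds, is how an amine or a carboxylic acid on the aryl ring would compare with the nitro group of the 4-nitrophenyl.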